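A few compounds are considered here, and "the series" means these few. Any claim that something is new, unique, unknown or untested is made for them only; others in the source may bear on it.

Of the compounds shown here, three with a shared core have been measured so far in a functional assay on DLD-1 cells (Homo sapiens) for cytotoxicity, with a stated time of 48 h (a lower number here means a stronger inhibitor, a higher number a weaker inhibitor), and their values sit close together. Compound 2 `C[S+]([O-])/C=C/c1cc(=O)c2ccccc2o1` gives 8000 nM and carries no extra group on the core. Compound 3 `COc1ccc2c(=O)cc(/C=C/[S+](C)[O-])oc2c1` gives 7800 nM with a methoxy group, and compound 1 `CCCCCOc1ccc2oc(/C=C/[S+](C)[O-])cc(=O)c2c1` gives 6600 nM with a pentyloxy group. Compound 2 therefore lies within the scatter of both. Compound 4 `C[S+]([O-])/C=C/c1cc(=O)c2cc(F)ccc2o1` has not been measured yet. It has fluoro in place of hydrogen on an aromatic carbon of compound 2 fluoro in place of hydrogen on an aromatic carbon and is otherwise the same.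

Going by the values given here, two measured steps bear on this change. The first, a 1.2-fold higher number from compound 1 to compound 2 (0.08 log units; within the scatter), is hydrogen in place of pentyloxy. The second, a 1.0-fold lower number from compound 2 to compound 3 (0.01 log units; within the scatter), is methoxy in place of hydrogen. Both stayed within the scatter, but neither involves fluoro, so the evidence is indirect. The expected change is a 1.1-fold lower number from compound 2 to compound 4 (0.03 log units; within the scatter) and so no shift beyond the scatter is anticipated. For compound 4 the estimated value is 7500 nM with an expected range from 4000 nM to 14000 nM in the same read-out.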

Compound 4, half-maximal inhibitory concentration: 7000 nM
For compound 4 the middle estimate is 1.1-fold (0.03 log units) above the measured one, and the stated range covers the measured number.
By their numbers in this assay, from the lowest: compounds 1, 4, 3 and 2 (each within the scatter of the next).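

In this assay, fluoro on this aromatic carbon, meta to a fused ring and para to a fused ring, gives a 1.1-fold lower number from compound 2 to compound 4 (0.06 log units; within the scatter), so this first halogen on the shared core does not separate from the unsubstituted compound. Exchanging the pentyloxy chain on the same carbon for a single fluorine atom gives a 1.1-fold higher number from compound 1 to compound 4 (0.03 log units; within the scatter), so at this position a small atom and a chain cannot be told apart in this read-out. No supporting data on these compounds are available to explain the result.

Every compound shown lies within the scatter of the others, so it remains open whether this carbon can influence the number at all. Going by these compounds, an amine or a carboxylic acid at the same place could test that, and whether either would produce a step beyond the scatter is unknown.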